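Amide series: cytotoxicity notes before compound 4 is measured

A few compounds are considered here, and "the series" means these few. Any claim that something is new, unique, unknown or untested is made for them only; others in the source may bear on it.

Measured so far:
compound 1 `O=C(CCSc1nnc(-c2ccncc2)s1)Nc1ccccc1Cl`; in an ADME assay on BHK-21 cells (Mesocricetus auratus) for cytotoxicity, with a stated time of 3 days (on this read-out lower numbers stand for higher toxicity in this test and higher numbers for lower toxicity in this test), compound 1 gives > 50000 nM, which is a limit of the assay.
compound 2 `O=C(CCSc1nnc(-c2ccncc2)s1)NCc1ccccc1`; in this assay compound 2 gives 18700 nM.
compound 3 `O=C(CSc1nnc(-c2ccncc2)s1)Nc1ccccc1Cl`; in this assay compound 3 gives > 50000 nM, again a limit of the assay.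

Compound 1 and compound 3 carry two cores whose difference is not broken down here. As far as these compounds go, in the first pair the change benzyl in place of 2-chlorophenyl on an amide-type nitrogen produced an at least 2.6-fold lower number from compound 1 to compound 2 (0.42 log units; beyond the scatter); its exact size stays open because the limit of > 50000 nM in this assay, at which 2 of the 3 values shown sit, fixes only the starting side.

Compound 4 `O=C(CSc1nnc(-c2ccncc2)s1)NCc1ccccc1` is not yet measured and carries the same change, (benzyl in place of 2-chlorophenyl on an amide-type nitrogen). For compound 4 the step of an at least 2.5-fold lower number from compound 3 to compound 4 (0.39 log units; beyond the scatter) is expected, beside the earlier one, resting on an at least 2.6-fold lower number from compound 1 to compound 2 (0.42 log units; beyond the scatter) and on the limit at which compound 3 sits. In this assay compound 4 is estimated at 20000 nM, expected to fall between 7000 nM and 50000 nM.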

Compound 4, half-maximal cytotoxic concentration: 11300 nM
For compound 4 the middle estimate is 1.8-fold (0.25 log units) above the measured one; the range from low to high includes it.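

In this assay, benzyl in place of 2-chlorophenyl on an amide-type nitrogen again lowers the number, an at least 4.4-fold lower number from compound 3 to compound 4 (0.64 log units; beyond the scatter), so the direction of the change holds on both cores shown. Two pairs show only that shared direction, not a rule for other cores, and whether the size of the step carries over stays unresolved: the same change on two cores in this assay, an at least 2.6-fold lower number (0.42 log units; beyond the scatter) from compound 1 to compound 2 and an at least 4.4-fold lower number (0.64 log units; beyond the scatter) from compound 3 to compound 4; the limit leaves it open whether they differ. Both steps start from a limit of the assay: the limit of > 50000 nM in this assay, at which 2 of the 4 values shown sit.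

The compounds shown do not separate the loss of the chlorine from the insertion of the carbon link in this change, as a plain phenyl or a 2-chlorobenzyl on that nitrogen would. Also open, as far as these compounds go, is how a longer chain such as phenethyl on the same nitrogen would read in this assay.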